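This account rests on a few compounds, and the source may have more. Where it says the series, first, only, none or still open, it means among the compounds named here.

Working notes on the series.

Three compounds carry measurements so far. Compound 1 `COC(=O)[C@H](CCSC)NC(=O)c1ccc(CN(Cc2c[nH]cn2)Cc2c[nH]cn2)cc1-c1ccccc1C` gives > 10 uM in a functional assay on NIH3T3 cells (Mus musculus) (on this read-out higher numbers stand for an effect only at larger amounts of compound and lower numbers for an effect already at smaller amounts), which is a limit of the assay and not a number. Compound 2 `N#CCNC(=O)c1ccc(NCc2cncn2Cc2ccc(C#N)cc2)cc1-c1ccccc1` likewise gives > 10 uM in this assay, again a limit rather than a number. Compound 3 `COC(=O)[C@H](CCSC)NC(=O)c1ccc(NCc2cncn2Cc2cccc([N+](=O)[O-])c2)cc1-c1ccccc1` sits at > 10 uM in this assay, once more a limit and not a number. On the numbers shown, compound 3 therefore stands nowhere distinct: all that is known is the limit of > 10 uM in this assay, at which 3 of the 3 values shown sit, so no ordering among the three can be read from this assay.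

The next member is compound 4 `COC(=O)[C@H](CCSC)NC(=O)c1ccc(NCc2cncn2Cc2ccc(C)cc2)cc1-c1ccccc1`, which differs from compound 3 in one place: 4-methylphenyl in place of 3-nitrophenyl on a saturated chain carbon bound to an aromatic nitrogen. Among the compounds with values here, no measured pair in the set differs in a single place, so no measured step exists against which this change could be sized.

Given that every value so far is a limit, the step expected in this assay is a step that the limit leaves unreadable from compound 3 to compound 4, that is, no change beyond the usual scatter, with the outcome most likely again a limit rather than a number. Compound 4 is accordingly expected near 15 uM, with a range from 5 uM to 50 uM.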

Compound 4, concentration for half-maximal effect: > 10 uM
Compound 4 was reported as a limit; the forecaster's own chance of this, stated with the estimate: 70%; the middle value is on the limit's open side.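

Compound 4 gives > 10 uM in this assay, a limit of the assay and not a number. Within the data shown here, compound 3 also stands at a limit, so no step between these two compounds can be read. Left open is how the four compounds rank in this assay and whether 4-methylphenyl in place of 3-nitrophenyl alters the effect, the only reading being: the limit of > 10 uM in this assay, at which 4 of the 4 values shown sit.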